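Mirror-Image Switch of a Nitro-Substituted Receptor Agonist

The compounds below may be only part of what the source reports. "The series", "measured", "known", "first", "only" and "open" are said of these compounds alone.

Compound 1 `Clc1ccc(N2CC[C@@H]3CN[C@@H]3C2)cn1`: 24 nM
Compound 2 `COc1ccc(N2CC[C@@H]3CN[C@@H]3C2)cn1`: 4980 nM
Compound 3 `O=[N+]([O-])c1ccc(N2CC[C@H]3CN[C@H]3C2)cn1`: 100 nM

In a functional assay on HEK293 cells for agonist activity at Neuronal acetylcholine receptor; alpha4/beta2 (Homo sapiens), read by FLIPR (a lower number here means that less compound is needed, a higher number that more compound is needed for the effect), compound 3 gives the second highest of three numbers, standing nearer to compound 1 than to compound 2. Among the measured compounds shown here, the one measured step, a 210-fold higher number from compound 1 to compound 2 (2.32 log units; beyond the scatter), concerns a group on the aromatic ring and says nothing about configuration. Compound 4 `O=[N+]([O-])c1ccc(N2CC[C@@H]3CN[C@@H]3C2)cn1` differs from compound 3 only in this way: the two compounds have the same atoms and bonds and differ only in configuration as drawn: 2 of 2 stereo elements differ (all stereocentres are inverted: mirror images); a stereocentre at a saturated ring carbon is drawn S in compound 3 and R in compound 4; a stereocentre at a saturated ring carbon is drawn R in compound 3 and S in compound 4. For the measured compounds named here, compounds 1 and 2 share the configuration drawn for compound 4, but no measured pair differs in configuration alone, so no step bears directly on this change. Mirror images often differ in this assay, so compound 4 is expected to show a step of a 1.7-fold lower number from compound 3 to compound 4 (0.22 log units; within the scatter), with considerable uncertainty about direction. Compound 4 is estimated at 60 nM, within 8 nM to 800 nM.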

Compound 4, half-maximal effective concentration: 110 nM
Estimate against measurement, compound 4: 1.8-fold (0.26 log units) below; the measured number falls inside the stated range.
By their numbers in this assay, from the lowest: compound 1; then compounds 3 and 4 (each within the scatter of the next); then compound 2.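

In this assay, inverting both stereocentres gives a 1.1-fold higher number from compound 3 to compound 4 (0.04 log units; within the scatter), so this mirror-image pair shows no measurable preference, and the comparison isolates configuration: the fact that compounds 3 and 4 differ only in the configuration as drawn. Within the configuration shared with compounds 1 and 2, nitro in place of methoxy gives a 45-fold lower number from compound 2 to compound 4 (1.66 log units; beyond the scatter), while nitro in place of chloro gives a 4.6-fold higher number from compound 1 to compound 4 (0.66 log units; beyond the scatter). For these compounds, the group on the aromatic ring therefore matters far more than the configuration of the nitro compounds.

As far as these compounds go, whether the chloro and methoxy compounds would also match their mirror images remains open. So does how an amine or a nitrile on the aromatic ring would compare.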